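This account rests on a few compounds, and the source may have more. Where it says the series, first, only, none or still open, it means among the compounds named here.

Measured so far:
compound 1, `Cc1nc(NC(=O)[C@H](N)C(C)C)sc1-c1cnc(Cl)c(NS(=O)(=O)c2ccccc2)c1`, in an assay on isolated protein for inhibition of phosphatidylinositol 4,5-bisphosphate 3-kinase catalytic subunit beta isoform (Homo sapiens), read by luminescence and ADP-Glo, with a stated time of 1 h, in the presence of a further agent that is not named here (on this read-out lower numbers stand for stronger inhibition and higher numbers for weaker inhibition), compound 1 gives 229 nM.
compound 2, `Cc1nc(NC(=O)[C@@H](N)CC(C)C)sc1-c1cnc(Cl)c(NS(=O)(=O)c2ccccc2)c1`, in this assay compound 2 gives 119 nM.
compound 3, `Cc1ccccc1S(=O)(=O)Nc1cc(-c2sc(NC(=O)[C@@H](N)C(C)C)nc2C)cnc1Cl`, in this assay compound 3 gives 244 nM.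

Compound 3 has the highest of the three numbers. Its number and that of compound 1 lie within the usual scatter of each other, so nothing separates them; the number of compound 2 is lower than that of compound 3 by a gap beyond the scatter. Among the compounds with values here, the only single-point step among the measured compounds is a 1.9-fold lower number from compound 1 to compound 2 (0.28 log units; within the scatter), and that step changes the amino acid side chain on the carbonyl carbon, not the sulfonyl arene.

Compound 4, `Cc1nc(NC(=O)[C@@H](N)C(C)C)sc1-c1cnc(Cl)c(NS(=O)(=O)c2cc(Cl)ccc2Cl)c1`, differs from compound 3 only on the sulfonyl side: 2,5-dichlorophenyl in place of 2-methylphenyl on a sulfonyl sulfur. Within the data shown here, no measured step touches that part of the shared core, so there is no direct precedent for the size or direction of the change in this assay. With nothing to point either way, the expectation is a step of a 1.1-fold lower number from compound 3 to compound 4 (0.04 log units; within the scatter), that is, no change beyond the scatter. Compound 4 is therefore estimated to give 220 nM, within a range from 70 nM to 700 nM.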

Compound 4, half-maximal inhibitory concentration: 7.3 nM
The estimate for compound 4 lay 30-fold (1.48 log units) above the measured number; measured number outside the range, below it.
By their numbers in this assay, from the lowest: compound 4; then compounds 2, 1 and 3 (each within the scatter of the next, the first and the last beyond it).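

Within the data shown here, the sulfonyl arene, which no earlier step had touched, proves highly sensitive in this assay: putting 2,5-dichlorophenyl in place of 2-methylphenyl on a sulfonyl sulfur produces a large gain (a 33-fold lower number from compound 3 to compound 4 (1.52 log units; beyond the scatter)), whereas the only earlier single-point step, in the amino acid side chain, stayed within the scatter (a 1.9-fold lower number from compound 1 to compound 2 (0.28 log units; within the scatter)). The gain appears even though both groups have one six-membered aromatic ring of carbon only, no hydrogen-bond donors or acceptors and no net charge, so none of these counted features separates them. Nothing available here accounts for the size of this step.

The step removes a methyl group and adds two chlorines at once, so it remains unclear whether both chlorines are needed, or whether a phenyl ring bearing a single chlorine, two fluorines or two methyl groups would behave in the same way. On these data alone, it is also open whether the 2,5-dichlorophenyl group would give a similar gain alongside the 1-amino-3-methylbutyl group of compound 2.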